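Pyrrolidine series: methoxy to methyl on the aryl group

The compounds below may be only part of what the source reports. "The series", "measured", "known", "first", "only" and "open" are said of these compounds alone.

Working notes on three measured members of a shared core and one still open. Compound 1 `COc1ccc([C@]2(CO)NC[C@@H](O)[C@@H]2O)cc1` carries a methoxy-substituted phenyl ring on the core; compound 2 `C[C@]1(CO)NC[C@@H](O)[C@@H]1O` carries a methyl in that position instead of an aryl group, and compound 3 `COc1cccc([C@]2(CO)NC[C@@H](O)[C@@H]2O)c1` carries the methoxy group elsewhere on the phenyl ring. In an assay on isolated protein for inhibition of alpha-mannosidase (Canavalia ensiformis), tested at 1000 uM (on this read-out higher numbers stand for more inhibition at the one concentration tested (going by the name of the read-out) and lower numbers for less inhibition), compound 1 gives 0.2%. In this assay compound 2 gives 3.8% and compound 3 gives 0%. On these three numbers compound 1 stands within the scatter of both neighbours: its gap to compound 3 and its gap to compound 2 are both inside the usual scatter, so no ordering among the three can be read, and all three are essentially without effect at the concentration tested.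

The open member is compound 4 `Cc1ccc([C@]2(CO)NC[C@@H](O)[C@@H]2O)cc1`. Compared with compound 1 the change is methyl in place of methoxy on an aromatic carbon. Among the measured compounds shown here, no step between measured compounds is available for this change, and the three numbers in hand give no sign that any substituent on the aryl ring moves the read-out. The step from compound 1 to compound 4 is therefore expected to be a number 0.8 percentage points higher from compound 1 to compound 4 (within the scatter), none beyond the scatter. For compound 4 the expected value in this assay is 1%, with a range from 0% to 8%.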

Compound 4, a percentage reported as inhibition, at one concentration (the size of the read-out at that concentration, not a potency): 0%
Beside the measured number, compound 4's estimate is 1 percentage points above it, within the range that was stated.
By their numbers in this assay, from the lowest: compounds 3, 4, 1 and 2 (each within the scatter of the next).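

In this assay, the first step readable at this position is a number 0.2 percentage points lower from compound 1 to compound 4 (within the scatter), so methyl in place of methoxy on an aromatic carbon, para to a group of 9 heavy atoms, does not move the read-out beyond the scatter. Among the compounds shown here, the step adds a direct comparison to what the earlier compounds offered, since they shared no single-place change, but its reach is limited: with compound 1 at 0.2% and compound 4 at 0%, both lie at the bottom of the read-out, where a further loss of inhibition could not show. Nothing measured here bears on the reason for this flat result.

As far as these compounds go, it remains open whether any group on this aromatic carbon can lift the read-out clear of the scatter, and an amine, a carboxylic acid or a longer chain such as propyl on the shared core would test that. Also open, from the compounds shown here alone, is whether the same exchange stays silent in a compound whose inhibition is well above the bottom of the read-out, where a step in either direction could be seen.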